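Dimethylamino Analogue of a Diol Amide: Cytotoxicity Outlook

The compounds below may be only part of what the source reports. "The series", "measured", "known", "first", "only" and "open" are said of these compounds alone.

Compound 1 `O=C(/C=C/[C@H]1C[C@@H](O)[C@@H](O)C1)Nc1ccc(C(F)(F)F)cc1`: in an ADME assay on S2 cells (Drosophila melanogaster) for cytotoxicity, read by MTT assay (on this read-out higher numbers stand for an effect only at larger amounts of compound and lower numbers for an effect already at smaller amounts), compound 1 gives > 160000 nM, which is a limit of the assay and not a number.
Compound 2 `COc1ccc(NC(=O)/C=C/[C@H]2C[C@@H](O)[C@@H](O)C2)cc1`: in this assay compound 2 gives > 180000 nM, again a limit of the assay.
Compound 3 `CC(C)(C)c1ccc(NC(=O)/C=C/[C@H]2C[C@@H](O)[C@@H](O)C2)cc1`: in this assay compound 3 gives > 180000 nM, also a limit of the assay.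

Compound 3 therefore stands on a limit rather than a number, and the two other values shown are limits as well, with one value at the limit of > 160000 nM in this assay, at which 1 of the 3 values shown sits, and two at the limit of > 180000 nM in this assay, at which 2 of the 3 values shown sit. The next compound, compound 4 `CN(C)c1ccc(NC(=O)/C=C/[C@H]2C[C@@H](O)[C@@H](O)C2)cc1`, differs from compound 3 at one point: dimethylamino in place of tert-butyl on an aromatic carbon.

Two measured steps change the same position: a step that the two limits leave unreadable from compound 1 to compound 3 and a step that the two limits leave unreadable from compound 2 to compound 3. Neither can be read in size, since both ends sit on limits, so no direction of change can be drawn from them. Every group tried at this place has left the compound without a readable effect in this assay.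

Compound 4 is therefore expected to fall at 180000 nM, within 90000 nM to 360000 nM, most probably again only as a limit, so that the expected step of a number no higher from compound 3 to compound 4 (the limit leaves the size open) is no step beyond the scatter.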

Compound 4, half-maximal effective concentration: > 170000 nM
Compound 4 was reported as a limit; the forecaster's own chance of this, stated with the estimate: 85%; the middle value is on the limit's open side.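

The steps from compound 1, compound 2 and compound 3 to compound 4 cannot be read in size: all four values in this assay are limits, not numbers. The compounds shown leave open at what concentration any of them reaches its half-maximal effect, and whether swapping these groups changes it.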